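Cytotoxicity Limits Across Three Biaryl Amides and a Fourth

The source may hold more compounds than are shown below. What is called first, only, known or untested is meant among the compounds shown, and "the series" means these compounds.

Compound 1, `CC(C)N(Cc1cccc(OCCCCCC(=O)O)c1)C(=O)c1ccc(-c2cccc(N(C)C)c2)cc1`: in an ADME assay on HepG2 cells (Homo sapiens) for cytotoxicity, read by CellTiter-Glo and resazurin assay, with a stated time of 72 h (a higher number here means that more compound is needed for the effect, a lower number that less compound is needed), compound 1 gives > 26000 nM, a limit of the assay.
Compound 2, `CC(C)Oc1cccc(-c2ccc(C(=O)N(Cc3cccc(OCCCCCC(=O)O)c3)C(C)C)cc2)c1`: in this assay compound 2 gives > 26000 nM, again a limit.
Compound 3, `Cc1nnc(-c2cccc(-c3ccc(C(=O)N(Cc4cccc(OCCCCCC(=O)O)c4)C(C)C)cc3)c2)o1`: in this assay compound 3 gives > 26000 nM, likewise a limit.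

Compound 3 thus stands where every measured compound stands, at the limit of > 26000 nM in this assay, at which 3 of the 3 values shown sit. For the measured compounds named here, none of the measured steps can be read: a step that the two limits leave unreadable from compound 1 to compound 2, a step that the two limits leave unreadable from compound 1 to compound 3 and a step that the two limits leave unreadable from compound 2 to compound 3 are all hidden by the two limits on either side, so no size or direction is known for any of them.

Compound 4, `CC(C)N(Cc1cccc(OCCCCCC(=O)O)c1)C(=O)c1ccc(-c2ccc3c(c2)OCCO3)cc1`, differs from compound 3 in one place: 2,3-dihydro-1,4-benzodioxin-6-yl in place of 3-(5-methyl-1,3,4-oxadiazol-2-yl)phenyl on an aromatic carbon. Going by the values given here, no measured step bears on this change in a readable way; what the three measured compounds show is only that exchanges at this carbon, of groups of quite different make-up, have so far left the read-out at the limit. The expected step is therefore a step that the limit leaves unreadable from compound 3 to compound 4, not a change beyond the scatter. Compound 4 is estimated to give 30000 nM in this assay, with a range from 15000 nM to 100000 nM, and most likely to be reported as a limit once more.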

Compound 4, half-maximal effective concentration: > 21900 nM
Compound 4 gave a limit, no number; the forecaster's own chance of this, stated with the estimate: 85%; the middle value is on the limit's open side.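

In this assay compound 4 gives > 21900 nM, a limit of the assay. For the compounds shown here, no step from compound 1, compound 2 or compound 3 to compound 4 can be read. The compounds shown leave open where any of the four reaches its half-maximal effect, and whether the group on this aromatic carbon changes it.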